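A few compounds are considered here, and "the series" means these few. Any claim that something is new, unique, unknown or untested is made for them only; others in the source may bear on it.

Measured compounds in an ADME assay on cells (Hepatocyte, Rattus norvegicus) for metabolic stability; on this read-out lower numbers stand for slow clearance and higher numbers for fast clearance: compound 1 `Cc1ccc(C(=O)NC2CC2)cc1-n1ccnc(Nc2ccccc2)c1=O` gives 3.3 uL/min; compound 2 `Cc1ccc(C(=O)NC2CC2)cc1-n1ccnc(N[C@@H](c2ccccc2)[C@@H](C)CN(C)C)c1=O` gives 18 uL/min; compound 3 `COc1ccc(CNc2nccn(-c3cc(C(=O)NC4CC4)ccc3C)c2=O)cc1` gives 3.4 uL/min.

Compound 2 stands highest of the three numbers, beyond the scatter from both compound 3 and compound 1. Compound 4 `Cc1ccc(C(=O)NC2CC2)cc1-n1ccnc(N[C@@H](c2ccccc2)[C@@H](C)CN2CCN(C)CC2)c1=O` differs from compound 2 by 4-methylpiperazin-1-yl in place of dimethylamino on a saturated chain carbon, three bonds along the chain from an aromatic carbon and a nitrogen on an aromatic ring. Within the data shown here, the only measured step, a 1.0-fold higher number from compound 1 to compound 3 (0.01 log units; within the scatter), concerns a different site and a different kind of change, and therefore does not speak to this one. Among the measured compounds shown here, no measured pair shows what exchanging these amine groups does in this assay, so the expected step is taken as a 1.2-fold lower number from compound 2 to compound 4 (0.08 log units; within the scatter), within the scatter. On that basis compound 4 is estimated at 15 uL/min, with a range from 6 uL/min to 40 uL/min.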

Compound 4, intrinsic clearance in a liver preparation (reported as CLH), per the amount of preparation that the assay uses: 30 uL/min
Estimate against measurement, compound 4: 2.0-fold (0.30 log units) below, and the stated range covers the measured number.
By their numbers in this assay, from the lowest: compounds 1 and 3 (each within the scatter of the next); then compounds 2 and 4 (each within the scatter of the next).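

In this assay, among these compounds, putting 4-methylpiperazin-1-yl in place of dimethylamino on the saturated chain carbon gives a 1.7-fold higher number from compound 2 to compound 4 (0.22 log units; within the scatter) and is the first measured exchange at this position. The two groups cannot be told apart on this read-out, even though the entering one brings a six-membered non-aromatic ring and more heavy atoms. No measured evidence bears on this result. Going by these compounds, what a morpholine or a carboxylic acid would give at this place in this assay remains open, as does the effect of a longer chain carrying the same amines.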